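The source may report more compounds than this note shows. Statements on the series, on what has been measured and on what is new or still open speak of the compounds shown alone.

Compound 2 `CN1CCN(C(=O)c2c(NC(=O)NS(=O)(=O)c3ccccc3)sc3c2CCCCC3)CC1` is one of two compounds already tested in a functional assay on UACC-257 cells (Homo sapiens) for inhibition, with a stated time of 48 h; on this read-out higher numbers stand for weaker inhibition of growth and lower numbers for stronger inhibition of growth. In this assay compound 2 gives > 100000 nM, which is a limit of the assay rather than a number. Compound 1 `O=C(Nc1sc2c(c1C(=O)NNc1ccccc1)CCCCC2)NS(=O)(=O)c1ccccc1` carries anilinoamino instead of 4-methylpiperazin-1-yl on the carbonyl carbon. In this assay compound 1 gives > 100000 nM, again a limit. The step that the two limits leave unreadable from compound 1 to compound 2 therefore has no readable size, because of the limit of > 100000 nM in this assay, at which 2 of the 2 values shown sit.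

Compound 3 `O=C(Nc1sc2c(c1C(=O)NNc1ccc(Br)cc1)CCCCC2)NS(=O)(=O)c1ccccc1` has not been measured; it differs from compound 2 by ((4-bromophenyl)amino)amino in place of 4-methylpiperazin-1-yl on a carbonyl carbon. This change is closely related to the one between the two measured compounds, and both of those sit at the limit, so nothing beyond the scatter can be read from them. The estimated step that the limit leaves unreadable from compound 2 to compound 3 is expected to be no more than the scatter. Compound 3 is expected to give about 150000 nM, between 50000 nM and 1000000 nM, and most probably only a limit again.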

Compound 3, concentration for 50% growth inhibition: > 100000 nM
Compound 3: only a limit was reported; the forecaster's own chance of this, stated with the estimate: 85%; the middle value lies beyond the limit too.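

Within the data shown here, no step among compound 1, compound 2 and compound 3 can be read, because all three sit at the same limit: the limit of > 100000 nM in this assay, at which 3 of the 3 values shown sit.

The compounds shown leave open how strongly any of the three inhibits growth, and whether swapping the group on the carbonyl carbon makes any difference.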